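The compounds below may be only part of what the source reports. "The series", "measured", "known", "first", "only" and "open" are said of these compounds alone.

Measured in a functional assay on IMR-32 cells (Homo sapiens) for antiproliferative activity, read by MTT assay; a higher number here means a weaker inhibitor, a lower number a stronger inhibitor:
- compound 1 `Cc1c(-n2cc(COc3ccc(/C=C/C(=O)c4cc5c(cc4O)OC(C)(C)CC5)cc3)nn2)cccc1[N+](=O)[O-]`: "not active" (no number reported)
- compound 2 `CC(=O)c1ccc(-n2cc(COc3ccc(/C=C/C(=O)c4ccc5c(c4O)CCC(C)(C)O5)cc3)nn2)cc1`: 89600 nM
- compound 3 `Cc1ccc(-n2cc(COc3ccc(/C=C/C(=O)c4ccc5c(c4O)CCC(C)(C)O5)cc3)nn2)cc1Br`: "not active" (no number reported)

Compound 1 has no single number in this assay, and its result reads "not active" (no number reported). It shares that position with compound 3, which also reads "not active" (no number reported). The only figure in the set belongs to compound 2, at 89600 nM. Within the data shown here, the series therefore offers one numerical reference point and no measured step between compounds.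

Attention now turns to compound 4 `CCCCCn1cc(COc2ccc(/C=C/C(=O)c3cc4c(cc3O)OC(C)(C)CC4)cc2)nn1`, which has not yet been measured. The structural change is pentyl in place of 2-methyl-3-nitrophenyl on an aromatic nitrogen. Among the measured compounds shown here, none of the measured compounds carries a pentyl group at this place, so the data do not show what this swap does. Some movement toward the stronger side in this assay is expected, but only a modest one, taking compound 4 from no reported number to a weak measurable value. The reference for that expectation is compound 2 at 89600 nM. A result of no reported number remains a real possibility. If a number is obtained, compound 4 is estimated at 60000 nM, with an expected range of 20000 nM to 100000 nM.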

Compound 4, half-maximal inhibitory concentration: "not active" (no number reported)
No number was reported for compound 4; the estimate stays without a comparison.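

In this assay, among these compounds, compound 4 reads "not active" (no number reported) and compound 1 reads "not active" (no number reported), so no step between them can be read. Nothing available bears on this result. The compounds shown leave open whether pentyl and 2-methyl-3-nitrophenyl on the aromatic nitrogen differ at all in this assay.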